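Pyranone anilines: cyclopentyl in place of pentyl at the ring

The source may report more compounds than this note shows. Statements on the series, on what has been measured and on what is new or still open speak of the compounds shown alone.

Measured so far:
compound 1, `COc1cccc(Nc2cc(-c3ccccc3)oc(=O)c2)c1`, 0.74 uM
compound 2, `CCCCCc1cc(Nc2ccc(OC)cc2)cc(=O)o1`, 4.93 uM
compound 3, `O=c1cc(Nc2ccc(Br)cc2)cc(-c2ccccc2)o1`, 0.4 uM

In a functional assay on SK-BR-3 cells (Homo sapiens) for cytotoxicity, read by MTT assay, with a stated time of 72 h (a higher number here means that more compound is needed for the effect, a lower number that less compound is needed), compound 2 gives 4.93 uM, the highest number of the three. Compound 1 gives 0.74 uM and compound 3 gives 0.4 uM; both differ from compound 2 in more than one place, so no single step between measured compounds is available, and their values show only that compound 2 needs the most compound for the effect among these three.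

Compound 4, `COc1ccc(Nc2cc(C3CCCC3)oc(=O)c2)cc1`, is not yet measured in this assay. It differs from compound 2 in one place: cyclopentyl in place of pentyl on an aromatic carbon. Going by the values given here, no measured pair isolates this kind of change, so the direction rests on no direct precedent. The expectation is a small step, from compound 2 to compound 4, of about a 1.4-fold lower number from compound 2 to compound 4 (0.15 log units; within the scatter), not clearly beyond the scatter. For compound 4 the estimate in this assay is 3.5 uM, with a range from 1.2 uM to 10 uM.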

Compound 4, concentration for half-maximal effect: 4.73 uM
Compound 4: the middle estimate sits 1.4-fold (0.13 log units) below what was measured; measured number inside the range.
By their numbers in this assay, from the lowest: compounds 3 and 1 (each within the scatter of the next); then compounds 4 and 2 (each within the scatter of the next).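

In this assay, going by these compounds alone, cyclopentyl in place of pentyl gives a 1.0-fold lower number from compound 2 to compound 4 (0.02 log units; within the scatter), the first comparison that isolates a single place. At this position, on an aromatic carbon next to the ring oxygen, an open pentyl chain and a five-membered non-aromatic ring of the same five carbons therefore cannot be told apart in this assay, as the step lies within the scatter. No measurement at hand offers an explanation for this result.

From the compounds shown here alone, whether a shorter chain, a longer chain, an amine or a carboxylic acid at this position would give a step beyond the scatter remains open. Also open, going by these compounds, is whether cyclopentyl and pentyl would remain within the scatter of each other with a group other than methoxy on the aniline.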